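Fluoro in Place of Methoxy: An Expected Dose

The compounds below may be only part of what the source reports. "The series", "measured", "known", "first", "only" and "open" are said of these compounds alone.

Measured so far:
compound 1, `COc1cccc2cc(C(=O)O)cnc12` — in a functional assay on the whole organism (strain Sprague-Dawley) for inhibition, with Rattus norvegicus as the target (a higher number here means that more compound is needed for the effect, a lower number that less compound is needed), compound 1 gives 25 mg/kg
compound 2, `COc1cccc2cc(-c3nn[nH]n3)cnc12` — in this assay compound 2 gives 2.5 mg/kg
compound 3, `COc1ccc2ncc(C(=O)O)c(O)c2c1` — in this assay compound 3 gives > 50 mg/kg, which is a limit of the assay and not a number

Compound 2 holds the lowest of the two numbers; compound 1 is its nearest neighbour, and the step of a 10-fold lower number from compound 1 to compound 2 (1.00 log units; beyond the scatter) separates them. Compound 4, `Fc1cccc2cc(-c3nn[nH]n3)cnc12`, differs from compound 2 in one place: fluoro in place of methoxy on an aromatic carbon. For the measured compounds named here, no measured step concerns this change; the only step measured, a 10-fold lower number from compound 1 to compound 2 (1.00 log units; beyond the scatter), exchanges the acid for the tetrazole and says nothing about fluoro or methoxy. In this assay compound 4 is therefore expected to lie within the scatter of compound 2, at an estimated 4 mg/kg (range 1.5 mg/kg to 12 mg/kg), an expected step of a 1.6-fold higher number from compound 2 to compound 4 (0.20 log units; within the scatter).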

Compound 4, minimum effective dose: > 10 mg/kg
Compound 4: no number, only a limit; the forecaster's own chance of this, stated with the estimate: 10%; middle value at least 2.5-fold (0.39 log units) away from the limit.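

With the 2H-tetrazol-5-yl group kept, fluoro in place of methoxy on this aromatic carbon gives an at least 4.0-fold higher number from compound 2 to compound 4 (0.60 log units; beyond the scatter) in this assay. The earlier step concerned only the exchange of carboxy for the tetrazole; this one shows that the group on this aromatic carbon also matters to the dose. Compound 4 carries a limit of the assay and not a number, so the full size of the step stays unknown: the limit of > 10 mg/kg in this assay, at which 1 of the 4 values shown sits.

The compounds shown leave open whether the higher number follows from losing methoxy or from bringing in fluoro. An ethoxy group, a hydroxy group or an amine on this carbon would bear on that question.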